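Cytotoxicity limit in the series: compound 3 to compound 4

A few compounds are considered here, and "the series" means these few. Any claim that something is new, unique, unknown or untested is made for them only; others in the source may bear on it.

Measured so far in an ADME assay on MT4 cells (Homo sapiens) for cytotoxicity, read by MTT assay, with a stated time of 96 h; on this read-out lower numbers stand for higher toxicity in this test and higher numbers for lower toxicity in this test:
- compound 1 `FC(F)(F)c1ccc(-c2nn(-c3ccccc3)cc2CNc2ccc(Cl)cc2)cc1` gives > 100000 nM as a limit
- compound 2 `Cc1ccc(-c2nn(-c3ccccc3)cc2CNc2ccc(Br)cc2)cc1` gives > 100000 nM as a limit
- compound 3 `Cc1ccc(-c2nn(-c3ccccc3)cc2CNc2ccc(C(F)(F)F)cc2)cc1` gives > 100000 nM as a limit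

Compound 3 gives only a limit and no number, and the series as a whole stands at the limit of > 100000 nM in this assay, at which 3 of the 3 values shown sit, without exception. Compound 4 `Cc1ccc(-c2nn(-c3ccccc3)cc2CNc2ccc(Cl)cc2)cc1` is the next case. It carries chloro in place of trifluoromethyl on an aromatic carbon, para to a large group, so that 4-(trifluoromethyl)phenyl becomes 4-chlorophenyl, and the count reads chloro in place of trifluoromethyl on an aromatic carbon in full.

The closest measured change is a step that the two limits leave unreadable from compound 2 to compound 3 and involves trifluoromethyl in place of bromo, so it gives no size to carry over. Compound 1 also carries chloro in that place, and its entry of > 100000 nM is a limit as well. No step beyond the scatter is therefore expected in this assay, and no direction can be assigned. The expected change is a number no higher from compound 3 to compound 4 (the limit leaves the size open) in size. For compound 4 the estimated value is 100000 nM with an expected range of 60000 nM to 200000 nM and a report as a limit is the likeliest outcome.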

Compound 4, half-maximal cytotoxic concentration: > 100000 nM
Compound 4 was reported as a limit; the forecaster's own chance of this, stated with the estimate: 85%; the middle value lies on the limit itself.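

In this assay no step from compound 1, compound 2 or compound 3 to compound 4 can be read, since each value is a limit and not a number: the limit of > 100000 nM in this assay, at which 4 of the 4 values shown sit.

The compounds shown leave open where the half-maximal cytotoxic concentration of each one actually lies, and whether any of these group changes alters it.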